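A few compounds are considered here, and "the series" means these few. Any claim that something is new, unique, unknown or untested is made for them only; others in the source may bear on it.

Working notes on the series.

Among the compounds with values here, compound 1 `COc1ccc(-c2cc(-c3ccc(Cl)cc3)n(C3C(=O)Nc4ccc(Br)cc43)n2)cc1` is, in a functional assay on cells (Melanoma cell, Homo sapiens) for cytotoxicity, read by sulforhodamine B assay, with a stated time of 48 h (on this read-out lower numbers stand for stronger inhibition of growth and higher numbers for weaker inhibition of growth), the compound with the highest number of the two measured so far; compound 1 gives 49300 nM. Within the data shown here, its only measured neighbour is compound 2 `COc1ccc(-c2cc(-c3ccc(Cl)cc3)n(C3C(=O)Nc4ccc(Cl)cc43)n2)cc1`, which in this assay gives 46700 nM. Among the measured compounds shown here, the one step recorded between measured compounds, a 1.1-fold lower number from compound 1 to compound 2 (0.02 log units; within the scatter), changes a halogen on the shared core and leaves the rest of the molecule untouched.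

Compound 3 `O=C1Nc2ccc(Br)cc2C1n1nc(-c2ccc3ccccc3c2)cc1-c1ccc(Cl)cc1` is not yet measured in this assay. It differs from compound 1 at a different site: naphthalen-2-yl in place of 4-methoxyphenyl on an aromatic carbon. For the measured compounds named here, no measured step touches this group, so nothing recorded bears directly on the move from compound 1 to compound 3. Going by the values given here, what the two measured values show is that the shared core with the 4-methoxyphenyl group sits in the same region in both compound 1 and compound 2, and the single recorded step stayed within the scatter.

Among the compounds with values here, with no step to lean on, the number for compound 3 is expected close to that of compound 1, with a wide range to allow for the exchange of the aryl group. The step of a 1.2-fold lower number from compound 1 to compound 3 (0.09 log units; within the scatter) is therefore estimated as small, in either direction. Compound 3 is estimated at 40000 nM, within 14000 nM to 110000 nM.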

Compound 3, concentration for total growth inhibition: 22400 nM
Estimate against measurement, compound 3: 1.8-fold (0.25 log units) above; the range from low to high includes it.
By their numbers in this assay, from the lowest: compound 3; then compounds 2 and 1 (each within the scatter of the next).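

Within the data shown here, the aryl position on the aromatic carbon of the five-membered ring responds in this assay where the halogen exchange did not: the exchange of 4-methoxyphenyl for naphthalen-2-yl gives a 2.2-fold lower number from compound 1 to compound 3 (0.34 log units; beyond the scatter) and is the first step to lie beyond the scatter, whereas the chloro for bromo exchange gives a 1.1-fold lower number from compound 1 to compound 2 (0.02 log units; within the scatter) and stays within it. The size of the step is modest, and this single exchange removes the methoxy oxygen and adds a second six-membered aromatic ring together, so the result cannot be assigned to either part of the change. Nothing measured on these compounds accounts for the step.

The compounds shown leave open whether a plain phenyl, a naphthalen-1-yl or a 4-hydroxyphenyl group at this position would move the number in the same direction, which would help separate the loss of the methoxy group from the gain of the second ring. They also leave open whether the naphthalen-2-yl step holds on the chloro core of compound 2.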